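Aryl swap at the pyrimidine-like core: compound 3 outlook

A few compounds are considered here, and "the series" means these few. Any claim that something is new, unique, unknown or untested is made for them only; others in the source may bear on it.

The series rests on a shared core, seen in compound 1 `CCOC(=O)c1cnc(C)nc1NN1C(=O)C=C(C)C1=O` and compound 2 `CCOC(=O)c1cnc(-n2nc(C)cc2C)nc1NN1C(=O)C=C(C)C1=O`. In a functional assay on Jurkat cells for inhibition of nuclear factor NF-kappa-B complex (Homo sapiens) (a higher number here means a weaker inhibitor, a lower number a stronger inhibitor), compound 1 gives 16000 nM, and compound 2 gives 10000 nM. For the measured compounds named here, of the two numbers in this assay compound 2 has the lower one, but its only neighbour is compound 1, and the step of a 1.6-fold lower number from compound 1 to compound 2 (0.20 log units; within the scatter) stays within the scatter, so the two compounds cannot be separated on these data.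

Compound 3 `CCOC(=O)c1cnc(-c2ccc(OC)cc2)nc1NN1C(=O)C=C(C)C1=O` continues the change at the same position: 4-methoxyphenyl in place of 3,5-dimethyl-1H-pyrazol-1-yl on an aromatic carbon. Going by the values given here, the only measured step that bears on this position is a 1.6-fold lower number from compound 1 to compound 2 (0.20 log units; within the scatter), which exchanged a methyl for the pyrazolyl group without a change beyond the scatter. Among the compounds with values here, no measured pair carries a methoxyphenyl group, so the new substituent has no direct precedent here. On that basis the expected step of no change at the digits printed from compound 2 to compound 3 (within the scatter) is none beyond the scatter in this assay. Compound 3 is therefore estimated at 10000 nM in this assay, with a range from 3000 nM to 32000 nM.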

Compound 3, half-maximal inhibitory concentration: 900 nM
Beside the measured number, compound 3's estimate is 11-fold (1.05 log units) above it; the measured number lies below the stated range.
By their numbers in this assay, from the lowest: compound 3; then compounds 2 and 1 (each within the scatter of the next).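

The position between two ring nitrogen atoms proves responsive in this assay: the change from the pyrazolyl group to 4-methoxyphenyl gives an 11-fold lower number from compound 2 to compound 3 (1.05 log units; beyond the scatter), and the change from methyl to 4-methoxyphenyl gives an 18-fold lower number from compound 1 to compound 3 (1.25 log units; beyond the scatter), whereas methyl and 3,5-dimethyl-1H-pyrazol-1-yl could not be told apart. The position is therefore not indifferent to its substituent, and compound 3 is the only one of the three set apart from both others by steps beyond the scatter. Nothing at hand accounts for the size of these steps.

Which part of the 4-methoxyphenyl group carries the step stays open, since a plain phenyl group or a 4-hydroxyphenyl group at this place would be needed to separate the aromatic ring from its methoxy group. Also open, on these data alone, is whether the step survives on a core with a carboxylic acid in place of the ethoxycarbonyl group, and how a saturated amine such as morpholine would behave at the same position.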